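The source may hold more compounds than are shown below. What is called first, only, known or untested is meant among the compounds shown, and "the series" means these compounds.

Working notes on the series. In a functional assay on MCF7 cells (Homo sapiens) for inhibition, read by sulforhodamine B assay, with a stated time of 72 h (a lower number here means a stronger inhibitor of growth, a higher number a weaker inhibitor of growth), compound 1 `Cn1ccc2cc(-c3cnccc3/C=C/C(=O)O)ccc21` gives only a limit of the assay, > 10000 nM. Compound 2 `CNC(=O)/C=C/c1ccncc1-c1ccc2[nH]ccc2c1` likewise gives only a limit, > 10000 nM. Compound 3 `CNC(=O)CCc1ccncc1-c1ccc2ccccc2c1` also gives only a limit, > 10000 nM. Compound 3 thus stands at the limit of > 10000 nM in this assay, at which 3 of the 3 values shown sit, with no number of its own to place it against the others. Compound 4 `NNC(=O)CCc1ccncc1-c1ccc2ccccc2c1` is not yet measured; it differs from compound 3 by amino in place of methyl on an amide-type nitrogen. Among the compounds with values here, no step between measured compounds is at hand to guide the estimate. In this assay no step beyond the usual scatter is expected from compound 3 to compound 4, in either direction. Compound 4 is therefore expected to give about 15000 nM, estimated between 5000 nM and 50000 nM, most likely again reported only as a limit. The expected step is a step that the limit leaves unreadable from compound 3 to compound 4.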

Compound 4, concentration for 50% growth inhibition: > 10000 nM
Compound 4: a limit, no number; the forecaster's own chance of this, stated with the estimate: 85%; the middle value is on the limit's open side.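

Compound 3 and compound 4 both give only a limit in this assay, so no step can be read between them: the limit of > 10000 nM in this assay, at which 4 of the 4 values shown sit. The compounds shown leave open what change, if any, would bring a value inside the range of this assay.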